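Moving the oxygen: aryl ether to benzyl ether on the oxadiazole

The source may hold more compounds than are shown below. What is called first, only, known or untested is meant among the compounds shown, and "the series" means these compounds.

Measured compounds and their values:
compound 1, `Cc1ccc(C(=O)CCc2nnc(-c3ccccc3)o2)c(C)c1`, 36%
compound 2, `Cc1ccc(C(=O)CCc2nnc(-c3ccc([N+](=O)[O-])cc3)o2)c(C)c1`, 40%
compound 3, `COc1ccc(-c2nnc(CCC(=O)c3ccc(C)cc3C)o2)cc1`, 62.7%

Compound 3 stands highest of the three in a functional assay on the whole organism (strain Wistar) for inhibition, with Rattus norvegicus as the target, with stated times of 30 min and 2 h, at a dose of 20 mg/kg by the oral route; on this read-out higher numbers stand for more inhibition at the one dose given (going by the name of the read-out) and lower numbers for less inhibition; compound 2 lies a number 22.7 percentage points higher from compound 2 to compound 3 (beyond the scatter) and compound 1 lies a number 26.7 percentage points higher from compound 1 to compound 3 (beyond the scatter), both beyond the scatter, while compound 1 to compound 2 is a number 4 percentage points higher from compound 1 to compound 2 (within the scatter). Compound 4, `Cc1ccc(C(=O)CCc2nnc(COc3ccccc3)o2)c(C)c1`, differs from compound 3 by phenoxymethyl in place of 4-methoxyphenyl on an aromatic carbon. Among the measured compounds shown here, no measured step shows this rearrangement; the steps that bear on it only show that the 4-methoxyphenyl group of compound 3 carries its advantage over compounds 1 and 2. Losing that group, compound 4 is expected to fall back toward those two, a step of about a number 22.7 percentage points lower from compound 3 to compound 4 (beyond the scatter), giving an estimate of 40% (25% to 58%).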

Compound 4, a percentage reported as inhibition, in the whole organism at one dose (the size of the read-out at that dose, not a potency): 27.6%
Compound 4: the middle estimate sits 12.4 percentage points above what was measured; the measured number falls inside the stated range.
By their numbers in this assay, from the lowest: compounds 4, 1 and 2 (each within the scatter of the next, the first and the last beyond it); then compound 3.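

In this assay, the same atoms joined differently at this place do not read alike: with phenoxymethyl in place of 4-methoxyphenyl, the step is a number 35.1 percentage points lower from compound 3 to compound 4 (beyond the scatter). The advantage of compound 3 therefore does not follow from the atoms of the group alone, but depends on how they are joined. Set against plain phenyl, phenoxymethyl gives no separation, with a number 8.4 percentage points lower from compound 1 to compound 4 (within the scatter); nothing available here accounts for these results.

The compounds shown leave open whether a methoxy group on the ring of phenoxymethyl would recover the number of compound 3. They also leave open how an amine on that ring would read.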